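A few compounds are considered here, and "the series" means these few. Any claim that something is new, unique, unknown or untested is made for them only; others in the source may bear on it.

Working notes on the series. Within the data shown here, in an ADME assay on the whole organism (Rattus norvegicus, strain Sprague-Dawley) for pharmacokinetics, read by LC-MS, at a dose of 2 mg/kg by the oral route (a lower number here means that a smaller share of the oral dose reaches the circulation, a higher number that a larger share of the oral dose reaches the circulation), compound 2 `N#Cc1ccc(S(=O)(=O)N2C[C@H](S(=O)(=O)c3ccc(Cl)cc3)[C@](O)(CO)C2)c(Cl)c1` gives 100%, the highest of the three numbers so far, against compound 3 `N#Cc1ccc(S(=O)(=O)N2C[C@H](S(=O)(=O)c3ccc(Cl)cc3)[C@](O)(CO)C2)cn1` at 62% and compound 1 `N#Cc1ccc(S(=O)(=O)[C@H]2CN(S(=O)(=O)c3ccc(C#N)cc3Cl)C[C@@]2(O)CO)cc1` at 15%.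

Compound 4 `N#Cc1ccc(S(=O)(=O)N2C[C@H](S(=O)(=O)c3ccc(Cl)cn3)[C@](O)(CO)C2)c(Cl)c1` is the next to read, and its difference from compound 2 is 5-chloropyridin-2-yl in place of 4-chlorophenyl on a sulfonyl sulfur. In words, this is 5-chloropyridin-2-yl in place of 4-chlorophenyl on a sulfonyl sulfur.

Among the measured compounds shown here, two measured steps bear on this change, and both are large. The closer analogy is a number 38 percentage points lower from compound 2 to compound 3 (beyond the scatter), where a carbon-only aromatic ring also gives way to one with a hetero atom, though on the other sulfonyl sulfur. The step of a number 85 percentage points higher from compound 1 to compound 2 (beyond the scatter) is a change on the same aromatic ring that compound 4 alters, but it swaps cyano for chloro and leaves the ring atoms untouched.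

A drop beyond the scatter is therefore expected, similar in size to the step to compound 3. The expected change is a number 35 percentage points lower from compound 2 to compound 4 (beyond the scatter). The estimate for compound 4 is 65%, with an expected range of 35% to 95%.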

Compound 4, oral bioavailability: 62%
For compound 4 the middle estimate is 3 percentage points above the measured one, within the range that was stated.
By their numbers in this assay, from the lowest: compound 1; then compounds 3 and 4 (each within the scatter of the next); then compound 2.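

In this assay, among these compounds, this sulfonyl position had so far been changed only through its substituent, cyano to chloro, and it now proves sensitive to the ring atoms as well: with the chloro group kept, 5-chloropyridin-2-yl in place of 4-chlorophenyl gives a number 38 percentage points lower from compound 2 to compound 4 (beyond the scatter). The same ring still retains a clear gain over the 4-cyanophenyl of the earlier compound, with a number 47 percentage points higher from compound 1 to compound 4 (beyond the scatter). No measurement on hand accounts for either step.

Going by these compounds, it remains open whether the drop persists when the chloro group on the 5-chloropyridin-2-yl ring gives way to fluoro, methyl, methoxy or an amine. Also open, on these data alone, is how this assay reads when aromatic rings with a hetero atom stand on both sulfonyl sulfurs at once.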